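Exchanging One Aromatic Ring for Another: Compound 4

This account rests on a few compounds, and the source may have more. Where it says the series, first, only, none or still open, it means among the compounds named here.

Measured compounds:
- compound 1, `CC(C)(C)c1csc(N)c1C(=O)c1ccc(Cl)cc1`, gives 1%
- compound 2, `Cc1c(Br)sc(N)c1C(=O)c1ccc(Cl)cc1`, gives 1%
- compound 3, `CC(C)(C)Cc1c(-c2ccc(F)cc2F)sc(N)c1C(=O)c1ccc(Cl)cc1`, gives 1%

All three measurements come from an assay on CHO cells for displacement of a labelled ligand from adenosine receptor A1 (Homo sapiens), read by scintillation counting, tested at 10 uM; on this read-out lower numbers stand for less inhibition and higher numbers for more inhibition at the one concentration tested (going by the name of the read-out). In this assay compound 3 stands level with compounds 1 and 2 at the digits shown: the gap to compound 1 and the gap to compound 2 both lie within the scatter of repeated measurements, so no order among the three can be read from these numbers. The shared core carries the same amino group and the same (4-chlorophenyl)carbonyl group in each case, and none of the three compounds shows any marked inhibition.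

Compound 4, `Cc1ccc(-c2sc(N)c(C(=O)c3ccc(Cl)cc3)c2CC(C)(C)C)cc1`, differs from compound 3 in one place: 4-methylphenyl in place of 2,4-difluorophenyl on an aromatic carbon. The change is confined to the ring that sits on the aromatic carbon next to the ring sulfur, while the neopentyl group and the rest of the core stay in place.

Among the compounds with values here, no pair of measured compounds differs in only one place, so no measured step is available to guide the size of this change. Since every measured compound sits at the low end of this assay, the expected step from compound 3 to compound 4 is none beyond the scatter, a number 1 percentage points higher from compound 3 to compound 4 (within the scatter). Compound 4 is therefore estimated to give 2%, with a likely range from 0% to 12%.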

Compound 4, a percentage reported as inhibition, at one concentration (the size of the read-out at that concentration, not a potency): 1%
The estimate for compound 4 lay 1 percentage points above the measured number; measured number inside the range.
By their numbers in this assay, from the lowest: compounds 1, 2, 3 and 4 (each within the scatter of the next).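

Within the data shown here, this is the first pair that differs in only one place, so it gives the first direct reading of a change on the aromatic carbon next to the ring sulfur. In this assay, 4-methylphenyl in place of 2,4-difluorophenyl gives no change at the digits printed from compound 3 to compound 4 (within the scatter). Both compounds sit at the low end of the read-out, so this exchange of one substituted phenyl ring for another does not lift inhibition at the one concentration tested, and nothing available explains this result.

Because the pair starts from so little inhibition, it cannot show whether this position matters for the read-out at all. From the compounds shown here alone, it remains open whether an amine or a carboxylic acid on this phenyl ring, or a longer chain in place of the ring, would give a higher number.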